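The source may hold more compounds than are shown below. What is called first, only, known or untested is meant among the compounds shown, and "the series" means these compounds.

Values in a functional assay on PC-3 cells (Homo sapiens) for antiproliferative activity, read by WST assay, with a stated time of 3 days; a lower number here means a stronger inhibitor, a higher number a weaker inhibitor:

- Compound 1 `CCCOc1c(-c2cc(OC)c(OC)c(OC)c2)oc2ccccc2c1=O`: 11800 nM
- Compound 2 `CCN(CC)CCCCOc1c(-c2cc(OC)c(OC)c(OC)c2)oc2ccccc2c1=O`: 13700 nM

Within the data shown here, compound 2 stands within the scatter of compound 1, the only other compound with a number so far. Compound 3 `CCCN(CCC)CCCOc1c(-c2cc(OC)c(OC)c(OC)c2)oc2ccccc2c1=O` has not yet been measured. It differs from compound 2 by dipropylamino in place of (diethylamino)methyl on a saturated chain carbon, three bonds along the chain from an oxygen on an aromatic ring, which, cut one bond further out, reads as 4-(diethylamino)butyl to 3-(dipropylamino)propyl.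

Among the measured compounds shown here, only one measured step bears on this change, a 1.2-fold higher number from compound 1 to compound 2 (0.06 log units; within the scatter). It placed (diethylamino)methyl on the same chain carbon and stayed within the scatter. For the measured compounds named here, no measured pair varies the groups on the nitrogen, so that step is indirect evidence. On this basis, no step beyond the scatter is expected in this assay, and no direction is favoured. The estimate therefore stays close to compound 2 at 13700 nM, with a range wide enough to allow for the thin evidence.

The expected change is a 1.1-fold lower number from compound 2 to compound 3 (0.02 log units; within the scatter). Compound 3 is estimated at 13000 nM, with an expected range from 6000 nM to 28000 nM.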

Compound 3, half-maximal inhibitory concentration: 16800 nM
Beside the measured number, compound 3's estimate is 1.3-fold (0.11 log units) below it; the range from low to high includes it.
By their numbers in this assay, from the lowest: compounds 1, 2 and 3 (each within the scatter of the next).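

In this assay, among these compounds, the exchange of 4-(diethylamino)butyl for 3-(dipropylamino)propyl gives a 1.2-fold higher number from compound 2 to compound 3 (0.09 log units; within the scatter), the first measured pair in which the groups on the nitrogen differ, and it shows that this change in the amine together with the chain leaves the number within the scatter. Measured from the compound with hydrogen at that place on the chain, dipropylamino gives a 1.4-fold higher number from compound 1 to compound 3 (0.15 log units; within the scatter), so a second amine has now been placed there, and again the step stays within the scatter. No separate measurement bears on these results, so they remain observations in this one assay.

The compounds shown leave open whether a different group in place of dipropylamino, such as a morpholine, a piperidine, a primary amine or a carboxylic acid, would step beyond the scatter in this assay. They also do not separate the effect of the chain from that of the groups on the nitrogen, which a longer chain carrying dipropylamino would begin to do.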